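A Fluoro Substituent on the Phenyl Ring of Compound 1

The source may hold more compounds than are shown below. What is called first, only, known or untested is meant among the compounds shown, and "the series" means these compounds.

Compound 1 `C[C@H](Nc1nc2cc(Cl)c(F)cc2s1)c1ccccc1` gives 58900 nM in a functional assay on HeLa cells (Homo sapiens) for cytotoxicity, read by MTT assay, with a stated time of 24 h; on this read-out lower numbers stand for stronger inhibition and higher numbers for weaker inhibition. Two relatives have been measured in the same way: compound 2 `CC[C@H](Nc1nc2cc(Cl)c(F)cc2s1)c1ccccc1` gives 53300 nM, and compound 3 `Fc1ccc(NC(=S)NC2CCCCC2OCc2ccccc2)cc1Cl` gives 33800 nM. Compound 1 carries the largest of the three numbers, yet both of the others lie within the scatter of it, so the three compounds cannot be told apart on this read-out.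

The unmeasured compound 4 `C[C@H](Nc1nc2cc(Cl)c(F)cc2s1)c1ccc(F)cc1` differs from compound 1 in one place: fluoro in place of hydrogen on an aromatic carbon. Within the data shown here, the only single-point step measured so far, a 1.1-fold lower number from compound 1 to compound 2 (0.04 log units; within the scatter), concerns a saturated chain carbon rather than the aromatic ring, and no measured pair shows what a fluoro on this ring does. With nothing pointing either way, no step beyond the scatter is expected in this assay on going from compound 1 to compound 4.

Compound 4 is therefore expected at 52000 nM, within a range from 25000 nM to 110000 nM. This estimate for compound 4 amounts to a 1.1-fold lower number from compound 1 to compound 4 (0.05 log units; within the scatter).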

Compound 4, half-maximal inhibitory concentration: 61900 nM
For compound 4 the middle estimate is 1.2-fold (0.08 log units) below the measured one, and the stated range covers the measured number.
By their numbers in this assay, from the lowest: compounds 3, 2, 1 and 4 (each within the scatter of the next).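

The change from phenyl to 4-fluorophenyl gives a 1.1-fold higher number from compound 1 to compound 4 (0.02 log units; within the scatter) in this assay. Unlike the earlier step on the saturated chain, this is a measured change on the six-membered aromatic ring itself, and at this place, para to a large group, a single fluoro does not separate compound 4 from compound 1 on this read-out. Nothing at hand offers an explanation for this result.

The compounds shown leave open whether a different group at this same place, such as a methoxy, an amine or a carboxylic acid, would move the number beyond the scatter. They also leave open whether a fluoro elsewhere on this ring would stay within the scatter of compound 1.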